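Swapping the aryl ether group on a cytotoxicity read-out

The source may hold more compounds than are shown below. What is called first, only, known or untested is meant among the compounds shown, and "the series" means these compounds.

Compound 1 `Cc1cc(C)c(Oc2cc(Nc3ccc(C#N)cc3)ncc2[N+](=O)[O-])c(C)c1` reads 69900 nM in an ADME assay on MT4 cells (Homo sapiens) for inhibition, read by MTT assay, with a stated time of 5 days; on this read-out lower numbers stand for higher toxicity in this test and higher numbers for lower toxicity in this test
Compound 2 `Cc1cc(Br)c(Oc2cc(Nc3ccc(C#N)cc3)ncc2[N+](=O)[O-])c(Br)c1` reads 23600 nM in this assay

Going by the values given here, compound 2 holds the lower of the two numbers (23600 nM) and so shows the higher toxicity of the pair in this assay with compound 1 as its only neighbour. Compound 3 `N#Cc1ccc(Nc2cc(Oc3c(F)cc(F)cc3F)c([N+](=O)[O-])cn2)cc1` has not yet been measured. It carries 2,4,6-trifluorophenyl in place of 2,6-dibromo-4-methylphenyl on an oxygen on an aromatic ring and the shared core stays the same. Among the compounds with values here, only one measured step bears on this place. It is a 3.0-fold lower number from compound 1 to compound 2 (0.47 log units; beyond the scatter) and it is modest. That step brought in the 2,6-dibromo-4-methylphenyl group, which compound 3 gives up again, although the entering group differs from the 2,4,6-trimethylphenyl of compound 1. One step sets no rule, so the direction is uncertain, but a modest move towards a higher number is expected, no larger than the earlier step. The expected change is a 1.5-fold higher number from compound 2 to compound 3 (0.18 log units; within the scatter) and it remains an estimate. The value estimated for compound 3 is 36000 nM (range 13000 nM to 100000 nM).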

Compound 3, half-maximal cytotoxic concentration: 3540 nM
Beside the measured number, compound 3's estimate is 10-fold (1.01 log units) above it; the measured number lies below the stated range.
By their numbers in this assay, from the lowest: compound 3; then compound 2; then compound 1.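

In this assay the group on this oxygen moved the number further than the first pair had shown: 2,4,6-trifluorophenyl in place of 2,6-dibromo-4-methylphenyl gave a 6.7-fold lower number from compound 2 to compound 3 (0.82 log units; beyond the scatter). This change kept the count of heavy atoms at the same value and kept the single six-membered aromatic ring, so the shift arose with no change in either count. Set against 2,4,6-trimethylphenyl, the same group gave a 20-fold lower number from compound 1 to compound 3 (1.30 log units; beyond the scatter), which shows that this one position spans a large range on the read-out and that the two halogen-bearing groups, far from reading alike, stand clearly apart. No accompanying measurement speaks to the reason for these shifts.

The compounds shown leave open which part of the change carries the effect, since compound 3 differs from compound 2 in all three ring substituents at once. They also leave open how a ring bearing chlorine atoms or a methoxy group would read here, and what an amine linker in place of the oxygen would do to the number.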